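Adding a Carbamoyl Group to Compound 1: Expected Solubility

This account rests on a few compounds, and the source may have more. Where it says the series, first, only, none or still open, it means among the compounds named here.

Compound 1, `O=C(Nc1ccccc1)c1cc2cc([N+](=O)[O-])ccc2s1`, gives 10 ug/mL in a physicochemical assay for solubility; a lower number here means a less soluble compound, a higher number a more soluble compound.
Compound 2, `CC(C)(C)OC(=O)NCc1ccccc1NC(=O)c1cc2cc([N+](=O)[O-])ccc2s1`, gives < 5 ug/mL in this assay; this is a limit of the assay, not a number.
Compound 3, `NC(=O)c1cccc(NC(=O)c2ccc(-c3ccccc3)cc2)c1`, gives 25 ug/mL in this assay.

Among the two numbers shown, compound 1 gives the lower one and compound 3 the higher, and that gap lies beyond the usual scatter. The third value is a limit.

Compound 4, `NC(=O)c1cccc(NC(=O)c2cc3cc([N+](=O)[O-])ccc3s2)c1`, keeps the core of compound 1 and changes one place: carbamoyl in place of hydrogen on an aromatic carbon. Among the compounds with values here, only one measured step starts from compound 1, an at least 2.0-fold lower number from compound 1 to compound 2 (0.30 log units; that floor lies within the scatter), and it ends at the limit of < 5 ug/mL in this assay, at which 1 of the 3 values shown sits; the group that enters there is a different one, so it says little about a carbamoyl. Within the data shown here, compound 3 carries a carbamoyl on the same anilide ring but on another core, and no single-change step links it to compound 1, so its value shows only that a compound with this group can give a number in the assay.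

Among the measured compounds shown here, with no directly comparable step, the expectation for compound 4 is a change within the scatter or a modest rise: compound 4 is estimated at 15 ug/mL, with a range from 5 ug/mL to 45 ug/mL, which means an expected step of a 1.5-fold higher number from compound 1 to compound 4 (0.18 log units; within the scatter).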

Compound 4, solubility: 25 ug/mL
The estimate for compound 4 lay 1.7-fold (0.22 log units) below the measured number; measured number inside the range.
By their numbers in this assay, from the lowest: compound 1; then compounds 3 and 4 (each within the scatter of the next). At a limit, below all of these: compound 2.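

On the core of compound 1, the carbamoyl group sits on an aromatic carbon of a six-membered aromatic ring of carbon only, meta to a large group, and in this assay the change gives a 2.5-fold higher number from compound 1 to compound 4 (0.40 log units; beyond the scatter). This gives the first readable size for a single change on this core, and it shows that this position can take a group of 3 heavy atoms, with a hydrogen-bond donor and acceptor, while the value stays a number and moves beyond the scatter. The one other single change from compound 1 gives only a limit, not a number, so compound 2 sets no size against which this step can be compared: the limit of < 5 ug/mL in this assay, at which 1 of the 4 values shown sits.

As far as these compounds go, what remains open is whether the step belongs to the carbamoyl group itself or to its place on the ring, since a single group at a single place cannot separate the two. An amine or a carboxylic acid at this same place, or the same carbamoyl group at another place on this ring, would help to separate them.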